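A few compounds are considered here, and "the series" means these few. Any claim that something is new, unique, unknown or untested is made for them only; others in the source may bear on it.

Measured compounds:
Compound 1, `O=C(O)c1cn(Cc2ccc(-c3ccccc3)cc2)c2cc(NC[C@H]3CCNC3)c(F)cc2c1=O`: 100000 nM
Compound 2, `O=C(O)c1cn(Cc2ccc(-c3ccccc3)cc2)c2cc(N3C[C@H]4CCNC[C@H]4C3)c(F)cc2c1=O`: 61000 nM

In an assay on isolated protein for inhibition of DNA topoisomerase 1 (Homo sapiens), with a stated time of 15 min (on this read-out higher numbers stand for weaker inhibition and lower numbers for stronger inhibition), compound 1 gives 100000 nM and compound 2 gives 61000 nM. The step of a 1.6-fold lower number from compound 1 to compound 2 (0.21 log units; within the scatter) is covered by the scatter, so compound 2 cannot be told apart from compound 1 on these numbers. Compound 3, `CNCCCCNc1cc2c(cc1F)c(=O)c(C(=O)O)cn2Cc1ccc(-c2ccccc2)cc1`, has not yet been measured. It differs from compound 2 in one place: a group of 7 heavy atoms (5 carbon, 2 nitrogen; no ring) in place of a group of 9 heavy atoms (7 carbon, 2 nitrogen; one five-membered non-aromatic ring with 1 hetero atom, one six-membered non-aromatic ring with 1 hetero atom), on an aromatic carbon. For the measured compounds named here, only one measured step bears on this change: it too exchanged one amine-bearing group for another at the same aromatic carbon of the shared core, and it came to a 1.6-fold lower number from compound 1 to compound 2 (0.21 log units; within the scatter), which the scatter covers. Going by the values given here, on that basis no step beyond the scatter is expected in this assay for compound 3, and the single comparison available leaves the range wide. Compound 3 is therefore estimated at 80000 nM, with a range from 30000 nM to 200000 nM. The expected step for compound 3 is a 1.3-fold higher number from compound 2 to compound 3 (0.12 log units; within the scatter).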

Compound 3, half-maximal inhibitory concentration: 88300 nM
The estimate for compound 3 lay 1.1-fold (0.04 log units) below the measured number; low and high end bracket the measured number.
By their numbers in this assay, from the lowest: compounds 2, 3 and 1 (each within the scatter of the next).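

In this assay, placing the open-chain (4-(methylamino)butyl)amino group on this aromatic carbon, ortho to the fluoro group, in place of the two-ring amine comes to a 1.4-fold higher number from compound 2 to compound 3 (0.16 log units; within the scatter) and stays within the scatter. Exchanging pyrrolidin-3-yl for 3-(methylamino)propyl on the saturated chain carbon bound to the nitrogen comes to a 1.1-fold lower number from compound 1 to compound 3 (0.05 log units; within the scatter) and also stays within the scatter, so at this position compounds 1, 2 and 3, with and without a ring in the amine group, cannot be told apart. No measurement is at hand that would account for this.

Going by these compounds, it remains open whether a group without a basic amine, such as a hydroxyl or a morpholine, would move the number beyond the scatter at this position. A primary amine or a shorter chain at this position is equally untested here, as is any replacement of the carboxylic acid on the shared core.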